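One Added Methoxy on Compound 2

The compounds below may be only part of what the source reports. "The series", "measured", "known", "first", "only" and "open" are said of these compounds alone.

In a functional assay on HOP-62 cells (Homo sapiens) for inhibition, read by sulforhodamine B assay (a lower number here means a stronger inhibitor of growth, a higher number a weaker inhibitor of growth), compound 1 (`COc1cc(-c2ccc(-c3ccc(-c4nc5ccccc5[nH]4)cc3)cc2)cc(OC)c1OC`) gives 9430 nM and compound 2 (`COc1ccc(-c2ccc(-c3ccc(-c4nc5c(O)cccc5[nH]4)cc3)cc2)cc1OC`) gives 2210 nM as the lower of the two numbers, a gap beyond the usual scatter. Compound 3 (`COc1cc(-c2ccc(-c3ccc(-c4nc5c(O)cccc5[nH]4)cc3)cc2)cc(OC)c1OC`) differs from compound 2 in one place, with methoxy in place of hydrogen on an aromatic carbon. Among the measured compounds shown here, no measured pair shows this change alone, and no shift beyond the scatter is expected for it in this assay at this stage. The expected step of a 1.1-fold higher number from compound 2 to compound 3 (0.05 log units; within the scatter) is small. For compound 3 the estimate is 2500 nM with an expected range from 800 nM to 7500 nM in this read-out.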

Compound 3, concentration for 50% growth inhibition: 190 nM
Compound 3: middle estimate off by 13-fold (1.12 log units), on the high side; measured number outside the range, below it.
By their numbers in this assay, from the lowest: compound 3; then compound 2; then compound 1.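

In this assay the methoxy in place of hydrogen, ortho to a methoxy group, gives a 12-fold lower number from compound 2 to compound 3 (1.07 log units; beyond the scatter) and so shows that this position responds strongly to the change when the hydroxy group is present. With this methoxy present, the step that adds the hydroxy group is a 50-fold lower number from compound 1 to compound 3 (1.70 log units; beyond the scatter). Nothing at hand gives a cause for either step.

From the compounds shown here alone, whether an ethoxy group or an amine at this position would give a similar step remains open. So does the size of the hydroxy step without this methoxy.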